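Deacylation at the amide nitrogen of a quinoxaline bis-aniline

This account rests on a few compounds, and the source may have more. Where it says the series, first, only, none or still open, it means among the compounds named here.

Going by the values given here, the series so far has three measured members. Compound 1, `O=C(Nc1ccc2nc(Nc3ccc(Cl)c(Cl)c3)c(Nc3ccc(Cl)c(Cl)c3)nc2c1)c1ccco1`, carries a (furan-2-yl)carbonyl amide on the core; compound 2, `O=[N+]([O-])c1ccc2nc(Nc3ccccc3)c(Nc3ccccc3)nc2c1`, and compound 3, `O=[N+]([O-])c1ccc2nc(Nc3ccc(F)c(C(F)(F)F)c3)c(Nc3ccc(F)c(C(F)(F)F)c3)nc2c1`, carry a nitro group instead and differ in their aniline substituents. In a toxicity assay on HepG2 cells (Homo sapiens) for cytotoxicity, read by MTT assay, with a stated time of 24 h (on this read-out lower numbers stand for higher toxicity in this test and higher numbers for lower toxicity in this test), compound 1 gives 14800 nM. In this assay compound 2 gives 12600 nM and compound 3 gives 7750 nM. Compound 1 sits at the large-number end of the three, but neither compound 2 nor compound 3 is separated from it beyond the usual scatter, so the three numbers cannot be told apart on the present data.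

The next compound, compound 4, `Nc1ccc2nc(Nc3ccc(Cl)c(Cl)c3)c(Nc3ccc(Cl)c(Cl)c3)nc2c1`, is the amine obtained from compound 1: hydrogen in place of (furan-2-yl)carbonyl on a nitrogen on an aromatic ring. Among the compounds with values here, no measured pair in the set shows this change, so its effect is unknown here. Hydrogen in place of (furan-2-yl)carbonyl on a nitrogen on an aromatic ring is expected to move the number in this assay little, if at all, beyond the scatter, with compound 1 at 14800 nM as the only anchor. For compound 4 the expected step in this assay is a 1.2-fold lower number from compound 1 to compound 4 (0.09 log units; within the scatter). Compound 4 is therefore estimated at 12000 nM, within a range from 5000 nM to 30000 nM.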

Compound 4, half-maximal cytotoxic concentration: 25100 nM
Estimate against measurement, compound 4: 2.1-fold (0.32 log units) below; the range from low to high includes it.
By their numbers in this assay, from the lowest: compounds 3, 2, 1 and 4 (each within the scatter of the next, the first and the last beyond it).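

Going by these compounds alone, this is the first pair that differs in one place only, and in this assay taking the (furan-2-yl)carbonyl off the nitrogen on the aromatic ring gives a 1.7-fold higher number from compound 1 to compound 4 (0.23 log units; within the scatter) and leaves the ((furan-2-yl)carbonyl)amino and amino forms indistinguishable on this read-out. On this one pair, losing 7 heavy atoms, including the five-membered aromatic ring and the carbonyl, does not move the number beyond the scatter at this nitrogen. No supporting data bear on this result.

Within the data shown here, open is whether a different group on this nitrogen, such as acetyl, a methyl group or a longer alkyl chain, would also stay within the scatter, or whether only this amide and amine pair behaves this way. Also open, on these data alone, is whether the same change would read alike with other aniline substituents: compound 2 and compound 3 carry a nitro group in this place together with different anilines, and neither forms a one-place comparison with compound 1 or compound 4.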